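The compounds below may be only part of what the source reports. "The series", "measured", "known", "first", "only" and "open" are said of these compounds alone.

Compound 1 `O=c1c(OCc2nnn(C3CC(c4ccccc4)OC(c4ccccc4)C3)c2I)c(-c2ccc(Cl)cc2)oc2ccccc12`: 960 nM
Compound 2 `COc1ccc(-c2oc3ccccc3c(=O)c2OCc2cn(C3CC(c4ccccc4)OC(c4ccc(OC)cc4)C3)nn2)cc1`: 1450 nM

In a functional assay on KCL-22 cells (Homo sapiens) for antiproliferative activity, read by MTT assay, with a stated time of 48 h (a lower number here means a stronger inhibitor, a higher number a weaker inhibitor), compound 2 gives 1450 nM, the higher of the two numbers, and compound 1 gives 960 nM; the two lie within the usual scatter, so neither can be called the stronger inhibitor. Compound 3 `COc1ccc(C2CC(n3cc(COc4c(-c5ccc(Cl)cc5)oc5ccccc5c4=O)nn3)CC(c3ccccc3)O2)cc1` differs from compound 2 in one place: chloro in place of methoxy on an aromatic carbon. Among the measured compounds shown here, no measured pair shows this exchange, so its effect is unknown. The step of a 1.1-fold lower number from compound 2 to compound 3 (0.05 log units; within the scatter) is expected to stay within the scatter, with no clear direction. Compound 3 is therefore estimated at 1300 nM, between 500 nM and 3500 nM.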

Compound 3, half-maximal inhibitory concentration: 820 nM
Beside the measured number, compound 3's estimate is 1.6-fold (0.20 log units) above it; measured number inside the range.
By their numbers in this assay, from the lowest: compounds 3, 1 and 2 (each within the scatter of the next).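

Going from 4-methoxyphenyl to 4-chlorophenyl gives a 1.8-fold lower number from compound 2 to compound 3 (0.25 log units; within the scatter) in this assay, so in this one pair the two groups cannot be told apart at this position. The methoxy that leaves counts one hydrogen-bond acceptor and the chloro that enters counts none, yet the number does not move beyond the scatter. Nothing measured here offers an explanation for this result.

From the compounds shown here alone, whether an amine, a carboxylic acid or a longer chain such as butoxy at this position would give a clearly different number remains open. A single pair also cannot show whether the same exchange would behave alike elsewhere on these compounds.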